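Saturated pyridyl chain on the oxazolyl ketone core

The source may report more compounds than this note shows. Statements on the series, on what has been measured and on what is new or still open speak of the compounds shown alone.

Compound 1 `O=C(CCCCC#Cc1ccccn1)c1ncc(-c2ccccn2)o1` carries the shared core with a pyridin-2-yl joined to the chain through an alkyne. In an assay for inhibition of Fatty-acid amide hydrolase 1 (Rattus norvegicus) (on this read-out higher numbers stand for weaker inhibition and lower numbers for stronger inhibition), compound 1 gives 280 nM. Compound 2 `O=C(CCCCCCc1ccccc1C(=O)O)c1ncc(-c2ccccn2)o1` places a 2-carboxyphenyl at the end of a fully saturated chain. In this assay compound 2 gives > 600 nM, which is a limit of the assay and not a number. Of the two values shown, compound 2 thus sits at the weaker end, at the limit of > 600 nM in this assay, at which 1 of the 2 values shown sits, while compound 1 stands at a measured number.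

Compound 3 `O=C(CCCCCCc1ccccn1)c1ncc(-c2ccccn2)o1` is not yet measured. It differs from compound 2 in one place: pyridin-2-yl in place of 2-carboxyphenyl on a saturated chain carbon, six bonds along the chain from a carbonyl carbon. Compound 3 therefore carries the same pyridin-2-yl terminus as compound 1 but on the saturated chain of compound 2.

The step of an at least 4.0-fold lower number from compound 2 to compound 3 (0.60 log units; beyond the scatter) is expected to run toward stronger inhibition, beyond the scatter, since compound 1 with the same terminal group reaches 280 nM in this assay. Compound 3 is estimated at 150 nM, within a range from 40 nM to 600 nM.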

Compound 3, inhibition constant: 120 nM
Estimate against measurement, compound 3: 1.3-fold (0.10 log units) above, within the range that was stated.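

Pyridin-2-yl in place of 2-carboxyphenyl on a saturated chain carbon, six bonds along the chain from a carbonyl carbon, gives an at least 5.0-fold lower number from compound 2 to compound 3 (0.69 log units; beyond the scatter) in this assay, so this position on the saturated chain can carry a terminus that gives a measured number. Compound 2 stands at a limit of the assay and not at a number, so the step from it has no upper end: the limit of > 600 nM in this assay, at which 1 of the 3 values shown sits. With the pyridin-2-yl terminus kept, 2-(pyridin-2-yl)ethyl in place of 2-(pyridin-2-yl)ethynyl on a saturated chain carbon, four bonds along the chain from a carbonyl carbon, gives a 2.3-fold lower number from compound 1 to compound 3 (0.37 log units; beyond the scatter), which sets the saturated link against the alkyne directly and favours the saturated link in this pair.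

The step from 2-carboxyphenyl changes the ring and removes the carboxylic acid in one move, so a plain phenyl terminus would be needed to separate the two. On these data alone, a longer chain, a shorter chain and an amine at the terminus also remain open, since compound 1, compound 2 and compound 3 all share one chain length.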